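From tert-butyl to methyl: the step to compound 3

The source may report more compounds than this note shows. Statements on the series, on what has been measured and on what is new or still open speak of the compounds shown alone.

In an ADME assay on U-87MG ATCC cells (Homo sapiens) for cytotoxicity, read by MTT assay, with a stated time of 24 h (on this read-out lower numbers stand for stronger inhibition and higher numbers for weaker inhibition), compound 1 (`COc1cc(/C=C/C(=O)CC(=O)/C=C/c2cccc(C(F)(F)F)c2)ccc1O`) gives 88700 nM as its reading. Compound 2 (`COc1cc(/C=C/C(=O)CC(=O)/C=C/c2ccc(OCC(=O)OC(C)(C)C)c(C(F)(F)F)c2)ccc1O`) gives > 100000 nM in this assay and that is a limit of the assay, not a number. Compound 2 therefore stands on a limit alone.

Compound 3 (`COC(=O)COc1ccc(/C=C/C(=O)CC(=O)/C=C/c2ccc(O)c(OC)c2)cc1C(F)(F)F`) differs from compound 2 in one place (methyl in place of tert-butyl on an oxygen next to a carbonyl group) with methyl in place of tert-butyl on an oxygen next to a carbonyl group. Within the data shown here, only one measured step bears on this change, and only loosely: an at least 1.1-fold higher number from compound 1 to compound 2 (0.05 log units; that floor lies within the scatter) came with (tert-butoxycarbonyl)methoxy in place of hydrogen on an aromatic carbon. Among the measured compounds shown here, no measured step exchanges the tert-butyl itself. With compound 1 at 88700 nM without that whole group, no shift beyond the scatter is expected in this assay in either direction. The expected step is an at least 1.1-fold lower number from compound 2 to compound 3 (0.04 log units; that floor lies within the scatter) by this estimate and a report of only a limit would not be surprising. Compound 3 is estimated at 90000 nM with an expected range of 45000 nM to 170000 nM on this read-out.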

Compound 3, half-maximal inhibitory concentration: 90000 nM
Beside the measured number, compound 3's estimate shows no gap at the digits printed; measured number inside the range.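

With compound 3, the (methoxycarbonyl)methoxy group on this aromatic carbon gives a number in this assay, so a side chain of this kind can be set directly against hydrogen: the step is a 1.0-fold higher number from compound 1 to compound 3 (0.01 log units; within the scatter) and leaves the reading of compound 1 unchanged within the scatter. Compound 2 gives only a limit of the assay, not a number: the limit of > 100000 nM in this assay, at which 1 of the 3 values shown sits. The exchange of tert-butyl for methyl on the oxygen next to a carbonyl group can thus be read only as a floor, an at least 1.1-fold lower number from compound 2 to compound 3 (0.04 log units; that floor lies within the scatter) and how far the true step runs stays unfixed, so this pair shows neither a real difference between the two esters nor its absence.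

Going by these compounds, whether a free carboxylic acid in place of the methyl ester, an amide, or a longer chain between the oxygen and the carbonyl would move the number in this assay beyond the scatter remains open. All three compounds also carry the trifluoromethyl group, so what the core gives with a chloro group or a bare hydrogen there is not shown.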